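This account rests on a few compounds, and the source may have more. Where it says the series, first, only, none or still open, it means among the compounds named here.

Working notes on the shared core of compound 3 `C#CCSc1nc(Sc2nncs2)c(C#N)c(-c2cc(OC)c(OC)c(OC)c2)n1`. In a functional assay on PC-3 cells (Homo sapiens) for antiproliferative activity, read by MTT assay, with a stated time of 72 h (on this read-out higher numbers stand for weaker inhibition and lower numbers for stronger inhibition), compound 3 gives 10300 nM, the higher of the two numbers shown, although compound 1 `C#CCSc1nc(Sc2nnnn2CCN(C)C)c(C#N)c(-c2ccc(Cl)cc2)n1`, which in this assay gives 7170 nM, sits within the scatter of it. Compound 2 `C#CCSc1nc(Sc2ccccn2)c(C#N)c(-c2cc(OC)c(OC)c(OC)c2)n1` gives in this assay only a limit, > 10000 nM. Among the measured compounds shown here, the step that the limit leaves unreadable from compound 2 to compound 3 therefore cannot be read, and it is the only measured step that touches the group on a sulfur. Compound 4 `C#CCSc1nc(Sc2nc3ccccc3s2)c(C#N)c(-c2cc(OC)c(OC)c(OC)c2)n1` carries 1,3-benzothiazol-2-yl in place of 1,3,4-thiadiazol-2-yl on a sulfur. For the measured compounds named here, no readable step bears on this change; the single neighbouring step starts from a limit, so neither direction nor size can be taken from it. The expectation for compound 4 is accordingly a step of a 1.1-fold lower number from compound 3 to compound 4 (0.06 log units; within the scatter) that stays within the scatter, with a real chance that this assay again reports only a limit, as for one value already (the limit of > 10000 nM in this assay, at which 1 of the 3 values shown sits). The estimate for compound 4 in this assay is 9000 nM, with a range from 3000 nM to 30000 nM.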

Compound 4, half-maximal inhibitory concentration: > 20000 nM
Compound 4 ended at the assay's limit (the forecaster's own chance of this, stated with the estimate: 40%); at least 2.2-fold (0.34 log units) between middle value and limit.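

In this assay compound 4 is reported only as a limit of the assay: the limit of > 20000 nM in this assay, at which 1 of the 4 values shown sits.

Setting 1,3-benzothiazol-2-yl in place of 1,3,4-thiadiazol-2-yl on this sulfur, which adds a six-membered aromatic ring of carbon only, gives an at least 1.9-fold higher number from compound 3 to compound 4 (0.28 log units; that floor lies within the scatter), the first step at this position that can be read at all, though only as a floor. On these data alone, the added ring therefore brings no sign of stronger inhibition, while the true size of the step remains unknown and its floor alone does not establish a real weakening.

The steps from compound 2 to compound 3 and to compound 4 cannot be read, so pyridin-2-yl remains unplaced against both groups. Open, as far as these compounds go, is whether a carboxylic acid or a plain butyl chain on this sulfur would give a readable, clearly lower number in this assay.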